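This account rests on a few compounds, and the source may have more. Where it says the series, first, only, none or still open, it means among the compounds named here.

Among the measured compounds shown here, compound 2 `Cc1cc(C)c(-c2cccnc2)cc1NC(=O)c1ccc(OCc2ccccn2)cc1` gives 78 mL.min-1.g-1 in an ADME assay on microsomes from liver (Rattus norvegicus) for metabolic stability (on this read-out higher numbers stand for fast clearance and lower numbers for slow clearance), the higher of the two numbers measured so far, while compound 1 `Cc1cc(C)c(-c2nc3ccccc3[nH]2)cc1NC(=O)c1ccc(OCc2ccccn2)cc1` gives 21 mL.min-1.g-1. Compound 3 `Cc1cc(C)c(-c2ccc(N)cn2)cc1NC(=O)c1ccc(OCc2ccccn2)cc1` differs from compound 2 by 5-aminopyridin-2-yl in place of pyridin-3-yl on an aromatic carbon. For the measured compounds named here, the one measured step that bears on this, a 3.7-fold higher number from compound 1 to compound 2 (0.57 log units; beyond the scatter), shows that swapping the aromatic ring at this position can shift this assay modestly, yet no measured step adds an amino group to such a ring, so the direction is uncertain. Compound 3 is expected to come out near 55 mL.min-1.g-1, within 20 mL.min-1.g-1 to 150 mL.min-1.g-1. The expected step, a 1.4-fold lower number from compound 2 to compound 3 (0.15 log units; within the scatter), is a slight lowering, well inside a modest range.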

Compound 3, intrinsic clearance in microsomes: 32 mL.min-1.g-1
Estimate against measurement, compound 3: 1.7-fold (0.24 log units) above; the measured number falls inside the stated range.
By their numbers in this assay, from the lowest: compounds 1 and 3 (each within the scatter of the next); then compound 2.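

In this assay, 5-aminopyridin-2-yl in place of pyridin-3-yl gives a 2.4-fold lower number from compound 2 to compound 3 (0.39 log units; beyond the scatter) and shows that the number at this position can fall while a six-membered aromatic ring with 1 hetero atom stays in place. Against 1H-benzimidazol-2-yl, the same group gives a 1.5-fold higher number from compound 1 to compound 3 (0.18 log units; within the scatter) and so cannot be told apart from it here. Nothing measured explains these results. The step to compound 3 changes both the ring's attachment and the amino group, and the compounds shown do not separate the two. Plain pyridin-2-yl, or a methoxy group in place of the amine, would be needed to do so.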